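Methyl for fluoro on the aryl of a shared core

The source may report more compounds than this note shows. Statements on the series, on what has been measured and on what is new or still open speak of the compounds shown alone.

Compound 3 `Fc1ccc(C2=NN(c3nc(-c4ccc(Br)cc4)cs3)C(c3ccc4c(c3)OCCO4)C2)cc1` gives 4110 nM in a functional assay on B16-F10 cells (Mus musculus) for antiproliferative activity, read by MTT assay, with a stated time of 48 h; a lower number here means a stronger inhibitor, a higher number a weaker inhibitor. Two other members of the same series have been measured: compound 1 `COc1ccc(-c2csc(N3N=C(c4ccc(F)cc4)CC3c3ccc4c(c3)OCCO4)n2)cc1` gives 4430 nM in this assay, and compound 2 `COc1ccc(C2=NN(c3nc(-c4ccc(OC)cc4)cs3)C(c3ccc4c(c3)OCCO4)C2)cc1` gives 3010 nM. All three numbers lie within the usual scatter of one another, so compound 3 is neither set apart from compound 1 nor from compound 2 on these data. Compound 4 `Cc1ccc(C2=NN(c3nc(-c4ccc(Br)cc4)cs3)C(c3ccc4c(c3)OCCO4)C2)cc1` differs from compound 3 by methyl in place of fluoro on an aromatic carbon. Within the data shown here, no measured pair shows this exact exchange. The nearest measured steps are a 1.5-fold lower number from compound 1 to compound 2 (0.17 log units; within the scatter), an exchange at the same aromatic carbon, and a 1.1-fold lower number from compound 1 to compound 3 (0.03 log units; within the scatter), an exchange on another aryl of the core; both fall within the scatter, and together they suggest that substituent changes on these peripheral rings have so far moved the numbers little. On that basis no step beyond the scatter is expected in this assay for compound 4, and its estimated step is a 1.0-fold lower number from compound 3 to compound 4 (0.01 log units; within the scatter). Compound 4 is therefore expected to give about 4000 nM, with a range from 1800 nM to 9000 nM.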

Compound 4, half-maximal inhibitory concentration: 1680 nM
For compound 4 the middle estimate is 2.4-fold (0.38 log units) above the measured one; the whole stated range lies above it.
By their numbers in this assay, from the lowest: compounds 4, 2, 3 and 1 (each within the scatter of the next, the first and the last beyond it).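

In this assay, among these compounds, the change from 4-fluorophenyl to 4-methylphenyl gives the first step in this set that lies beyond the scatter (a 2.4-fold lower number from compound 3 to compound 4 (0.39 log units; beyond the scatter)), showing that a single exchange at this aromatic carbon, para to a large group, can move the number, if only modestly. The earlier exchange at the same carbon (a 1.5-fold lower number from compound 1 to compound 2 (0.17 log units; within the scatter)) stayed within the scatter, but it brought in methoxy rather than methyl and had methoxy rather than bromo on the other aryl, so the two steps differ in both the entering group and the surroundings of the change. There is no measurement here that accounts for the lower number with methyl in place of fluoro.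

Methyl at this carbon appears only with bromo on the other aryl, so it remains open whether the step would persist with methoxy there. As far as these compounds go, it is equally open how the number would respond to an ethyl chain, an amine or a carboxylic acid at this carbon, and so whether methyl marks a trend or an isolated result.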